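Chloro in place of nitro: compound 3 in prospect

A few compounds are considered here, and "the series" means these few. Any claim that something is new, unique, unknown or untested is made for them only; others in the source may bear on it.

- compound 1 `COc1cc2nc(SCC(=O)Nc3ccc(C)cc3)nc(Nc3c(Cl)cc(/C=C/C#N)cc3Cl)c2cc1OC`: 2540 nM
- compound 2 `COc1cc2nc([S+]([O-])CC(=O)Nc3cccc([N+](=O)[O-])c3)nc(Nc3c(Cl)cc(/C=C/C#N)cc3Cl)c2cc1OC`: >= 83200 nM

In an ADME assay on MT4 cells (Homo sapiens) for cytotoxicity, read by MTT assay, with a stated time of 5 days (on this read-out higher numbers stand for lower toxicity in this test and lower numbers for higher toxicity in this test), compound 2 is known only as a limit (>= 83200 nM). Compound 1 gives a measured number (2540 nM). Compound 3 `COc1cc2nc([S+]([O-])CC(=O)Nc3cccc(Cl)c3)nc(Nc3c(Cl)cc(/C=C/C#N)cc3Cl)c2cc1OC` has chloro in place of nitro on an aromatic carbon, meta to a large group (chloro in place of nitro on an aromatic carbon). Among the measured compounds shown here, no measured step covers this change, so only a moderate move towards lower numbers is expected in this assay, and another limit remains possible. The expected step is estimated (an at least 2.0-fold lower number from compound 2 to compound 3 (0.31 log units; beyond the scatter)). Compound 3 is expected near 40000 nM, with an estimated range of 12000 nM to 120000 nM.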

Compound 3, half-maximal cytotoxic concentration: 68900 nM
Compound 3: middle estimate off by 1.7-fold (0.24 log units), on the low side, within the range that was stated.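

In this assay, chloro in place of nitro at this position, meta to a large group, gives an at least 1.2-fold lower number from compound 2 to compound 3 (0.08 log units; that floor lies within the scatter). Among the compounds shown here, compound 3 brings the first measured number for this substitution pattern, 68900 nM, so the series now has a usable reference here. For compound 2 the figure is a limit and not a number, which leaves the true size of the step unread: the limit of >= 83200 nM in this assay, at which 1 of the 3 values shown sits.

Going by these compounds, whether an amine or a carboxylic acid at this position would give a similar number stays open. Compound 1 differs from compound 3 in more than one place and cannot settle this.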